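The compounds below may be only part of what the source reports. "The series", "measured", "known", "first", "only" and "open" are said of these compounds alone.

Compound 1 `CC1=C(N2CC2)C(=O)C(Cc2ccccc2)=C(N2CC2)C1=O` gives 4.69 in a functional assay on L1210 cells (Mus musculus), with a stated time of 12 days; a higher number here means a more potent compound, by a factor of ten per unit of this negative logarithm, a lower number a less potent compound. Going by the values given here, of the two numbers measured so far, compound 1 stands lowest; the nearest is compound 2 `CCOC(COC(N)=O)C1=C(N2CC2)C(=O)C(C)=C(N2CC2)C1=O`, which in this assay gives 5.22, a number higher by a gap beyond the usual scatter. Among the compounds with values here, compound 2 differs from compound 1 in more than one place, so no single step between measured compounds can be read from the pair, and their two values show only that compound 2 sits higher.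

Compound 3 `CC1=C(N2CC2)C(=O)C(C2CCCCC2)=C(N2CC2)C1=O` has not yet been measured. It differs from compound 1 in one place: cyclohexyl in place of benzyl on a double-bonded ring carbon. The group that leaves and the group that enters are both six-membered rings of carbon only, one aromatic and one non-aromatic, neither carrying hydrogen-bond donors or acceptors, and the place on the core is unchanged.

Within the data shown here, with no measured step of this kind to lean on, the step from compound 1 to compound 3 is expected to be a number 0.01 log units higher from compound 1 to compound 3 (within the scatter), that is, none beyond the scatter in either direction. For compound 3 the estimated value in this assay is 4.7, with a range from 4.2 to 5.3.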

Compound 3, logarithm of the reciprocal of the active concentration, log(1/C): 5.39
Compound 3: the middle estimate sits 0.69 log units below what was measured; the whole stated range lies below it.
By their numbers in this assay, from the lowest: compound 1; then compounds 2 and 3 (each within the scatter of the next).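

Going by these compounds alone, this is the first single-place step: in this assay, cyclohexyl in place of benzyl on the double-bonded ring carbon gives a number 0.70 log units higher from compound 1 to compound 3 (beyond the scatter). The position therefore responds to the group it carries: on the shared core, these two carbon-only groups, each with one six-membered ring and neither with hydrogen-bond donors or acceptors, are not interchangeable, and the non-aromatic cyclohexyl stands on the higher side of the pair. Nothing measured bears on the reason for the size of this step.

The step changes two things at once, the aromatic ring for a non-aromatic one and the benzyl for a group with one heavy atom fewer, so the pair cannot separate them; phenyl and cyclohexylmethyl at the same place would pull the two apart. Also open, on these data alone, is how the position treats groups outside this carbon-only ring type, such as a longer alkyl chain, an amine or a carboxylic acid.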